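A Hydroxy-to-Ethyl Exchange on a Weakly Active Scaffold

The source may hold more compounds than are shown below. What is called first, only, known or untested is meant among the compounds shown, and "the series" means these compounds.

Measured compounds:
- compound 1 `O=c1[nH]c2ccccc2cc1/C=N/CCO` — "not active" (no number reported)
- compound 2 `Cc1ccc2[nH]c(=O)c(/C=N/Nc3ccc([N+](=O)[O-])cc3[N+](=O)[O-])cc2c1` — "not active" (no number reported)
- compound 3 `Cc1ccc2[nH]c(=O)c(/C=N/CCO)cc2c1` — 498000 nM

Of the compounds shown here, three sharing the same core have been tested in a functional assay, read by spectrophotometry, with a stated time of 30 min; on this read-out higher numbers stand for weaker inhibition and lower numbers for stronger inhibition. Compound 1 is reported in this assay as "not active" (no number reported), with no number attached. Compound 2 likewise gives "not active" (no number reported) in this assay. Only compound 3 carries a numerical read-out, giving 498000 nM in this assay, which marks it as a very weak inhibitor. Within the data shown here, compound 1 thus stands among the entries without a single number, and no step between measured compounds is available for this series.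

Compound 4 `CCCC/N=C/c1cc2ccccc2[nH]c1=O` has not yet been measured in this assay. It differs from compound 1 by ethyl in place of hydroxy on a saturated chain carbon, two bonds along the chain from a double-bonded nitrogen. Because compound 1 is reported as "not active" (no number reported) and the only numbered relative, compound 3, is far from potent at 498000 nM, a step of any size beyond the scatter is difficult to foresee here; the expectation is for no clear movement toward stronger inhibition.

Compound 4 is therefore estimated at 500000 nM in this assay, with an expected range from 100000 nM to 3000000 nM, and it is considered quite likely that the assay again reports no number at all.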

Compound 4, half-maximal inhibitory concentration: 439000 nM
Beside the measured number, compound 4's estimate is 1.1-fold (0.06 log units) above it; the range from low to high includes it.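

In this assay, among these compounds, compound 1 gives "not active" (no number reported) while compound 4 gives 439000 nM and so no step between the two can be read. The compounds shown leave open whether ethyl in place of hydroxy at this place changes inhibition on the shared core. No measurement shown here bears on the result.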